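Swapping Bromo for Iodo on Compound 3

The source may hold more compounds than are shown below. What is called first, only, known or untested is meant among the compounds shown, and "the series" means these compounds.

In an ADME assay on WI-38 cells (Homo sapiens) for cytotoxicity, read by MTT assay, with a stated time of 72 h (a lower number here means a stronger inhibitor, a higher number a weaker inhibitor), compound 1 `O=C(CCc1cccc2c1B(O)OC2)Nc1ccc(F)cc1` gives 12000 nM while compound 3 `O=C(CCc1cccc2c1B(O)OC2)Nc1cccc(Br)c1` gives 20000 nM on the same scale. The gap is a 1.7-fold higher number from compound 1 to compound 3 (0.22 log units; within the scatter) so these two sit together. Compound 2 `Cc1ccc(NC(=O)CCc2cccc3c2B(O)OC3)cc1` reads > 100000 nM as its result, and that is a limit of the assay. Against it, compound 3 stands apart, with an at least 5.0-fold lower number from compound 2 to compound 3 (0.69 log units; beyond the scatter) as the step. Compound 4 `O=C(CCc1cccc2c1B(O)OC2)Nc1cccc(I)c1` alters compound 3 in one place only (iodo in place of bromo on an aromatic carbon) with iodo in place of bromo on an aromatic carbon. The large steps, an at least 8.3-fold higher number from compound 1 to compound 2 (0.92 log units; beyond the scatter) and the one just given, both involve the methyl compound, and this change involves no methyl. The closer guide is a 1.7-fold higher number from compound 1 to compound 3 (0.22 log units; within the scatter) as a change from one halogen-bearing compound to another, though only these two compounds support it. An estimated step of a 1.1-fold lower number from compound 3 to compound 4 (0.05 log units; within the scatter) is therefore expected in this assay and should stay within the scatter. For compound 4 the expected value is 18000 nM with an estimated range from 7000 nM to 50000 nM in this measurement.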

Compound 4, half-maximal inhibitory concentration: 71000 nM
Beside the measured number, compound 4's estimate is 3.9-fold (0.60 log units) below it, and the stated range ends below it.
By their numbers in this assay, from the lowest: compounds 1 and 3 (each within the scatter of the next); then compound 4. At a limit, above all of these: compound 2.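

Changing a single atom, bromo to iodo on an aromatic carbon meta to a large group, shifts the reading in this assay, with a 3.6-fold higher number from compound 3 to compound 4 (0.55 log units; beyond the scatter). Compound 4 also separates from the fluoro compound, with a 5.9-fold higher number from compound 1 to compound 4 (0.77 log units; beyond the scatter), so the halogens at hand do not all read alike in this series. Compound 2 is held at a limit and not a number, which leaves an at least 1.4-fold lower number from compound 2 to compound 4 (0.14 log units; that floor lies within the scatter) as a floor only: the limit of > 100000 nM in this assay, at which 1 of the 4 values shown sits.

Still open, going by these compounds, is whether chloro at this same place would read with compound 3 or with compound 4, and how an amine or a carboxylic acid there would read. Compound 1 also differs from compound 3 and compound 4 in both its halogen and that halogen's place on the ring, so these two changes remain unseparated.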